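Ring-nitrogen aryl group: 2,6-dimethoxyphenyl versus 2,5-dimethoxyphenyl

The source may hold more compounds than are shown below. What is called first, only, known or untested is meant among the compounds shown, and "the series" means these compounds.

Compound 1 `COc1ccc(OC)c(N2C(=O)CSC2c2cccc(C(=O)NCCCCc3ccccc3)c2)c1` carries a 2,5-dimethoxyphenyl on the amide-type nitrogen in the ring. Within the data shown here, in a functional assay on U2OS cells (Homo sapiens) for inhibition, read by CCK-8 assay, with a stated time of 72 h, tested at 1 uM (a higher number here means more inhibition at the concentration tested (going by the name of the read-out), a lower number less inhibition), compound 1 gives 1%, the lowest of the three numbers measured so far. Compound 2 `CCN1C(=O)CSC1c1cccc(C(=O)NCCCCc2ccccc2)c1` gives 13% and compound 3 `COc1cc(F)ccc1N1C(=O)CSC1c1cccc(C(=O)NCCCCc2ccccc2)c1` gives 34%. Both steps away from compound 1 run upward: a number 12 percentage points higher from compound 1 to compound 2 (beyond the scatter) and a number 33 percentage points higher from compound 1 to compound 3 (beyond the scatter). Between the two other compounds, a number 21 percentage points higher from compound 2 to compound 3 (beyond the scatter).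

Compound 4 `COc1cccc(OC)c1N1C(=O)CSC1c1cccc(C(=O)NCCCCc2ccccc2)c1` differs from compound 1 only at that nitrogen: 2,6-dimethoxyphenyl in place of 2,5-dimethoxyphenyl on an amide-type nitrogen in a ring. Among the measured compounds shown here, no measured step exchanges one dimethoxyphenyl for another, so the two steps from compound 1 are the nearest guide; each of them raised inhibition beyond the scatter, but they differ widely in size, and here the same atoms are merely joined differently. A modest rise is expected, a number 14 percentage points higher from compound 1 to compound 4 (beyond the scatter). Compound 4 is accordingly estimated at 15%, with a range from 0% to 38%; a result within the scatter of compound 1 cannot be excluded.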

Compound 4, a percentage reported as inhibition, at one concentration (the size of the read-out at that concentration, not a potency): 41%
Compound 4: middle estimate off by 26 percentage points, on the low side, outside the stated range (above it).
By their numbers in this assay, from the lowest: compound 1; then compound 2; then compounds 3 and 4 (each within the scatter of the next).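

In this assay, the same atoms joined differently at the amide-type nitrogen are enough for a large step (a number 40 percentage points higher from compound 1 to compound 4 (beyond the scatter)), so the placement of the methoxy groups matters here, not just their presence. The 2,6-dimethoxyphenyl and 4-fluoro-2-methoxyphenyl groups cannot be told apart at this nitrogen (a number 7 percentage points higher from compound 3 to compound 4 (within the scatter)), whereas the 2,6-dimethoxyphenyl group stands clearly apart from ethyl (a number 28 percentage points higher from compound 2 to compound 4 (beyond the scatter)), which leaves the 2,5-dimethoxyphenyl group as the low point among the groups compared at this position. Nothing available accounts for this dependence on placement.

Open, from the compounds shown here alone, is whether both methoxy groups of the 2,6-dimethoxyphenyl group are needed, or whether a 2-methoxyphenyl or plain phenyl group would read the same. Also open, going by these compounds, is how 2,6-dimethylphenyl or 2,6-difluorophenyl would compare at this nitrogen.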